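Swapping methoxy for trifluoromethyl on a biguanide

The compounds below may be only part of what the source reports. "The series", "measured", "known", "first", "only" and "open" are said of these compounds alone.

Compound 1 `CNC(=N)NC(=N)Nc1ccc(Cl)cc1` gives 1.58 in a physicochemical assay for lipophilicity, in phosphate buffer, measured as octanol-water partition, at pH 11.5; on this read-out lower numbers stand for lower lipophilicity and higher numbers for higher lipophilicity. Compound 2 `CCCCCCS(=O)(=O)c1ccc(NC(=N)NC(=N)NCCCCCCNC(=N)NC(=N)Nc2ccc(S(=O)(=O)CCCCCC)cc2)cc1` gives 5.1, and compound 3 `CCCCCCCCNC(=N)NC(=N)Nc1ccc(OC)cc1` gives 4.41. Among these three numbers compound 3 stands second highest: compound 2 sits higher by a gap beyond the scatter, and compound 1 sits far lower, also beyond the scatter. Compound 4 `CCCCCCCCNC(=N)NC(=N)Nc1ccc(C(F)(F)F)cc1` has not yet been measured. It differs from compound 3 in one place: trifluoromethyl in place of methoxy on an aromatic carbon. Among the compounds with values here, since no measured pair shows this exchange directly, the size of the step rests on expectation alone; a moderate rise beyond the scatter is expected, with the step from compound 3 to compound 4 estimated at a number 0.89 log units higher from compound 3 to compound 4 (beyond the scatter). Compound 4 is therefore expected to give about 5.3, within a range from 4.8 to 5.8.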

Compound 4, partition coefficient: 5.31
Estimate against measurement, compound 4: 0.01 log units below; measured number inside the range.
By their numbers in this assay, from the lowest: compound 1; then compound 3; then compounds 2 and 4 (each within the scatter of the next).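

In this assay, trifluoromethyl in place of methoxy on an aromatic carbon, para to a large group, gives a directly measured step at this position: a number 0.90 log units higher from compound 3 to compound 4 (beyond the scatter). Everything else in the two structures is the same, so the step belongs to this one exchange, which also removes the single hydrogen-bond acceptor of methoxy. Nothing measured here accounts for the size of the step.

As far as these compounds go, whether the exchange gives a similar step on a longer chain or another core stays open. So does the number that a nitrile, an amine or a carboxylic acid would give at this position.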